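One Ring Swap, Tested Twice, on Rat Cell Toxicity

The source may report more compounds than this note shows. Statements on the series, on what has been measured and on what is new or still open speak of the compounds shown alone.

Of the compounds shown here, three have been measured in an ADME assay on L6 cells (Rattus norvegicus) for cytotoxicity, read by resazurin assay, with a stated time of 70 h; on this read-out lower numbers stand for stronger inhibition and higher numbers for weaker inhibition. Compound 1 `CC(C)NC(=N)c1ccc2oc(-c3cccc(OCCCOc4ccccc4)c3)cc2c1` gives 26500 nM. Compound 2 `c1ccc(OCCCOc2cccc(-c3cc4cc(C5=NCCN5)ccc4o3)c2)cc1` gives 6500 nM, the lowest of the three numbers. Compound 3 `CC(C)NC(=N)c1ccc2cc(-c3cccc(OCCCCOc4ccccc4)c3)oc2c1` gives 46500 nM; compounds 1 and 3 differ in more than one place, and the difference between their two cores is not broken down here. Compound 2 arises from compound 1 by a group of 5 heavy atoms (3 carbon, 2 nitrogen; one five-membered non-aromatic ring with 2 hetero atoms) in place of a group of 6 heavy atoms (4 carbon, 2 nitrogen; no ring), on an aromatic carbon, and this change produced a 4.1-fold lower number from compound 1 to compound 2 (0.61 log units; beyond the scatter). Compound 4 `c1ccc(OCCCCOc2cccc(-c3cc4ccc(C5=NCCN5)cc4o3)c2)cc1` stands to compound 3 as compound 2 stands to compound 1: a group of 5 heavy atoms (3 carbon, 2 nitrogen; one five-membered non-aromatic ring with 2 hetero atoms) in place of a group of 6 heavy atoms (4 carbon, 2 nitrogen; no ring), on an aromatic carbon, at a position described in the same words, so it is the same change carried onto the other core. Compound 4 has not yet been measured in this assay. For compound 4 the expected step is a 4.2-fold lower number from compound 3 to compound 4 (0.63 log units; beyond the scatter), because the earlier step was a 4.1-fold lower number from compound 1 to compound 2 (0.61 log units; beyond the scatter), a single precedent that is the only support here. For compound 4 an outcome around 11000 nM is estimated, likely falling between 5000 nM and 25000 nM.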

Compound 4, half-maximal inhibitory concentration: 5800 nM
The estimate for compound 4 lay 1.9-fold (0.28 log units) above the measured number; low and high end bracket the measured number.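

In this assay, replacing the open-chain group on the aromatic carbon with the five-membered ring gave an 8.0-fold lower number from compound 3 to compound 4 (0.90 log units; beyond the scatter), so the swap that lowered the number on the core of compound 1 also lowered it on the core of compound 3. The two steps point the same way, and their sizes cannot be told apart: the same change on two cores in this assay, a 4.1-fold lower number (0.61 log units; beyond the scatter) from compound 1 to compound 2 and an 8.0-fold lower number (0.90 log units; beyond the scatter) from compound 3 to compound 4, 2.0-fold (0.29 log units) apart, within the scatter of two such steps. Among the compounds shown here, this shows that the swap carried over between these two cores in this one cell assay, but with only two pairs it does not show that it would carry over to any other core, nor does it explain why the number falls.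

The compounds shown leave open what other groups at this place on the core, such as an amine or a carboxylic acid, would do to the number. They also leave open whether the size of the step would stay the same with a longer chain on either core.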